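Trimming the pyrazole substituents in a glucagon receptor antagonist series

The source may report more compounds than this note shows. Statements on the series, on what has been measured and on what is new or still open speak of the compounds shown alone.

Compound 1, `CCCC(Oc1ccc(-n2cc(C(F)(F)F)c(C)n2)cc1)c1ccc(C(=O)NCCC(=O)O)cc1`: 8300 nM
Compound 2, `CCC(Oc1ccc(-n2cc(C(F)(F)F)cn2)cc1)c1ccc(C(=O)NCCC(=O)O)cc1`: > 22000 nM
Compound 3, `CC(C)(C)C(Oc1ccc(-n2cc(C(F)(F)F)cn2)cc1)c1ccc(C(=O)NCCC(=O)O)cc1`: 4300 nM

Of the compounds shown here, three sharing one core have been measured in a functional assay on cells for antagonist activity at Glucagon receptor (Homo sapiens), read by cAMP accumulation, in the presence of a further agent that is not named here; a higher number here means a weaker inhibitor, a lower number a stronger inhibitor. In this assay compound 1 gives 8300 nM, the higher of the two plain numbers. Compound 3 gives 4300 nM, and the gap from compound 1 to compound 3 lies within the scatter, so no order between the two can be claimed. Compound 2 sits at a limit of the assay, (the limit of > 22000 nM in this assay, at which 1 of the 3 values shown sits).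

Among the compounds with values here, the one measured step between neighbours is an at least 5.1-fold lower number from compound 2 to compound 3 (0.70 log units; beyond the scatter). It concerns the chain carbon that carries the ether oxygen and says nothing about the pyrazole ring.

Compound 4, `CCCC(Oc1ccc(-n2cc(F)cn2)cc1)c1ccc(C(=O)NCCC(=O)O)cc1`, differs from compound 1 by 4-fluoro-1H-pyrazol-1-yl in place of 3-methyl-4-(trifluoromethyl)-1H-pyrazol-1-yl on an aromatic carbon. Within the data shown here, no measured step touches the pyrazole substituents, so the direction of this change is unsupported by the data. Compound 4 is therefore expected to give a number near that of compound 1, estimated at 15000 nM, within 5000 nM to 45000 nM, which means an expected step of a 1.8-fold higher number from compound 1 to compound 4 (0.26 log units; within the scatter).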

Compound 4, antagonist equilibrium constant: 10000 nM
Compound 4: the middle estimate sits 1.5-fold (0.18 log units) above what was measured; measured number inside the range.
By their numbers in this assay, from the lowest: compounds 3, 1 and 4 (each within the scatter of the next, the first and the last beyond it). At a limit, above all of these: compound 2.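

Within the data shown here, exchanging 3-methyl-4-(trifluoromethyl)-1H-pyrazol-1-yl for 4-fluoro-1H-pyrazol-1-yl gives a 1.2-fold higher number from compound 1 to compound 4 (0.08 log units; within the scatter) in this assay, the first measured step at this position on the aromatic ring. On the core of compound 1, the methyl and trifluoromethyl groups can therefore give way to a single fluorine with no difference that this measurement can resolve, so the larger group is not shown to be needed here. Nothing measured here explains why the two pyrazole groups read alike.

Because both groups leave in one step, this result cannot show what the methyl or the trifluoromethyl contributes alone. Also open, going by these compounds, is how a chlorine or a nitrile would compare with the fluorine on the pyrazole, and whether tert-butyl on the chain carbon would give a different number when paired with 4-fluoro-1H-pyrazol-1-yl.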